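The source may report more compounds than this note shows. Statements on the series, on what has been measured and on what is new or still open speak of the compounds shown alone.

Within the data shown here, compound 1, with the structure `Cc1cc(S(=O)(=O)/N=C(\N)n2nccc2-c2ccccc2)c(SCc2cccc(Cl)c2)cc1Cl`, is the stronger of the two compounds measured so far. In a functional assay on HeLa cells (Homo sapiens) for cytotoxicity, read by MTT assay, with a stated time of 72 h (a lower number here means a stronger inhibitor, a higher number a weaker inhibitor), compound 1 gives 10000 nM. Compound 2, with the structure `Cc1cccc(CSc2cc(Cl)c(C)cc2S(=O)(=O)/N=C(\N)n2nc(C)cc2-c2ccccc2)c1`, gives 155000 nM in this assay, a higher number that lies beyond the usual scatter, so compound 1 stands lowest of the two. Compound 3, with the structure `Cc1cc(S(=O)(=O)/N=C(\N)n2nccc2-c2ccccc2)c(SCc2ccccc2C(F)(F)F)cc1Cl`, is not yet measured. It differs from compound 1 in a single place: 2-(trifluoromethyl)phenyl in place of 3-chlorophenyl on a saturated chain carbon bound to a sulfur. Among the measured compounds shown here, no measured pair of compounds shows an exchange of this kind, so there is no observed step to rest on; the shared core and the sulfur-bound chain are unchanged, and only the ring at the end of that chain is swapped. The expected step, a 1.2-fold higher number from compound 1 to compound 3 (0.08 log units; within the scatter), is estimated to stay within the scatter, with no clear direction. Compound 3 is therefore expected to give about 12000 nM, in a range from 4000 nM to 40000 nM.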

Compound 3, half-maximal inhibitory concentration: 20000 nM
Compound 3: the middle estimate sits 1.7-fold (0.22 log units) below what was measured, within the range that was stated.
By their numbers in this assay, from the lowest: compounds 1 and 3 (each within the scatter of the next); then compound 2.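

Among these compounds, the exchange of 3-chlorophenyl for 2-(trifluoromethyl)phenyl on a saturated chain carbon bound to a sulfur gives a 2.0-fold higher number from compound 1 to compound 3 (0.30 log units; within the scatter) in this assay and is the first change in a single place that can be read in this set. At this place, then, a ring end of 10 heavy atoms in place of 7, carrying a different group, gives a number that stays within the scatter of the original, so the two ring ends cannot be told apart here. Nothing shown explains this result.

On these data alone, a ring end carrying an amine or a carboxylic acid, or a longer chain between the sulfur and the ring, remains open. Compound 2 differs from compound 1 in more than one place, so the source of its higher number cannot be read.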